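This account rests on a few compounds, and the source may have more. Where it says the series, first, only, none or still open, it means among the compounds named here.

Measured so far:
compound 1 `CC(C(=O)NCc1ccc(C(F)(F)F)nc1NC1CCCCC1)c1ccc(NS(C)(=O)=O)c(F)c1` gives 20.4 nM in a functional assay on CHO-K1 cells for antagonist activity at transient receptor potential cation channel subfamily V member 1 (Homo sapiens), read by FLIPR; a higher number here means a weaker inhibitor, a lower number a stronger inhibitor.
compound 2 `Cc1ccc(CC2CCN(c3nc(C(F)(F)F)ccc3CNC(=O)C(C)c3ccc(NS(C)(=O)=O)c(F)c3)CC2)cc1` gives 0.2 nM.
compound 3 `CC(C(=O)NCc1ccc(C(F)(F)F)nc1N1CCC(Cc2ccc(F)c(F)c2)CC1)c1ccc(NS(C)(=O)=O)c(F)c1` gives 0.2 nM.

Compound 3 stands level with compound 2, and the two share the lowest numbers of the three; compound 1 sits well higher, beyond the scatter. Going by the values given here, the only single-point step measured, no change at the digits printed from compound 2 to compound 3 (within the scatter), swaps one aryl for another and leaves the number unchanged. Compound 4 `CC(C(=O)NCc1ccc(C(F)(F)F)nc1N1CCC(O)CC1)c1ccc(NS(C)(=O)=O)c(F)c1` goes further and removes the aryl altogether: hydroxy in place of 3,4-difluorobenzyl on a saturated ring carbon. Among the compounds with values here, no measured step covers this removal, but compound 1, which carries no such aryl, gives 20.4 nM, so a sizeable loss is expected. The expected step is a 150-fold higher number from compound 3 to compound 4 (2.18 log units; beyond the scatter). For compound 4 the estimate is 30 nM, with a range from 5 nM to 200 nM.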

Compound 4, inhibition constant: "not active" (no number reported)
No number was reported for compound 4; there is nothing to compare the estimate with.
By their numbers in this assay, from the lowest: compounds 2 and 3 (each within the scatter of the next); then compound 1.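

Going by these compounds alone, compound 4 is reported as "not active" with no number, so no step from compound 3 to compound 4 can be read. No available data bear on the cause of this result. For this assay the compounds shown leave open which groups smaller than 3,4-difluorobenzyl on that saturated ring carbon still give a number.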